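This account rests on a few compounds, and the source may have more. Where it says the series, first, only, none or still open, it means among the compounds named here.

Measured compounds:
- compound 1, `COC(=O)[C@H]1O[C@@H](Oc2c(O)cc(O)c3c(=O)cc(-c4ccccc4)oc23)[C@H](O)[C@@H](O)[C@@H]1O` — in a functional assay on RAW264.7 cells (Mus musculus) for inhibition, read by Griess assay (on this read-out lower numbers stand for stronger inhibition and higher numbers for weaker inhibition), compound 1 gives > 30000 nM, which is a limit of the assay rather than a number.
- compound 2, `COc1ccccc1[C@@H]1CC(=O)c2c(O)cc(O[C@@H]3O[C@H](CO)[C@@H](O)[C@H](O)[C@H]3O)c(OC)c2O1` — in this assay compound 2 gives > 30000 nM, also a limit.
- compound 3, `COC(=O)[C@H]1O[C@@H](Oc2cc(O)c3c(c2OC)O[C@H](c2cccc(OC)c2)CC3=O)[C@H](O)[C@@H](O)[C@@H]1O` — in this assay compound 3 gives > 30000 nM, again a limit.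

Compound 1 therefore stands at the limit, and so do the two other measured compounds; none of the three shows a measurable inhibition. The evidence is summed up in the limit of > 30000 nM in this assay, at which 3 of the 3 values shown sit. Within the data shown here, no step between two measured compounds is available, so nothing shows how a change in structure moves this read-out.

The unmeasured compound 4, `O=C(O)[C@H]1O[C@@H](Oc2c(O)cc(O)c3c(=O)cc(-c4ccccc4)oc23)[C@H](O)[C@@H](O)[C@@H]1O`, differs from compound 1 in a single place: hydrogen in place of methyl on an oxygen next to a carbonyl group. Among the measured compounds shown here, with compound 1 at the limit of this assay and no measured step to lean on, the expectation is that compound 4 also ends at the limit, and the step that the limit leaves unreadable from compound 1 to compound 4 is expected to be none beyond the scatter. Compound 4 is thus estimated at 50000 nM, with a range from 20000 nM to 200000 nM, most likely reported as a limit again.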

Compound 4, half-maximal inhibitory concentration: > 30000 nM
Compound 4 was reported as a limit; the forecaster's own chance of this, stated with the estimate: 85%; the middle value lies beyond the limit too.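

Compound 1 and compound 4 both give only a limit in this assay, and the change from methoxycarbonyl to carboxy between them cannot be read as a step. The compounds shown leave open which change in structure, if any, would give a measurable value: the limit of > 30000 nM in this assay, at which 4 of the 4 values shown sit.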